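The source may hold more compounds than are shown below. What is called first, only, known or untested is meant among the compounds shown, and "the series" means these compounds.

The series shares one core carrying a substituted sulfanyl chain and an arylhydrazone arm, and is followed in a functional assay on ECa-109 cells (Homo sapiens) for antiproliferative activity, read by MTT assay, with a stated time of 72 h; on this read-out higher numbers stand for weaker inhibition and lower numbers for stronger inhibition. Compound 1 `CCCSc1nc(N/N=C(\C)c2ccc(O)cc2)c2nnn(Cc3ccccc3)c2n1` gives 32500 nM in this assay. Compound 2 `C#CCSc1nc(N/N=C/c2ccc(N(C)C)cc2)c2nnn(Cc3ccccc3)c2n1` gives 31300 nM in this assay; compound 1 and compound 2 differ in two places at once, and their two numbers lie within the scatter of each other. For the measured compounds named here, compound 3 `C#CCSc1nc(N/N=C/c2c(O)ccc3ccccc23)c2nnn(Cc3ccccc3)c2n1` gives 6520 nM in this assay, the lowest of the three numbers; the only single-point step measured, a 4.8-fold lower number from compound 2 to compound 3 (0.68 log units; beyond the scatter), sits on the hydrazone arm and not on the sulfanyl chain.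

Compound 4 `CCCSc1nc(N/N=C/c2c(O)ccc3ccccc23)c2nnn(Cc3ccccc3)c2n1` differs from compound 3 by ethyl in place of ethynyl on a saturated chain carbon bound to a sulfur. Going by the values given here, no measured step isolates this change: compound 1 carries propylsulfanyl and compound 2 carries propargylsulfanyl, but they differ elsewhere as well, and their values in this assay lie within the scatter of each other, so nothing in the set points either way. The step of a 1.1-fold higher number from compound 3 to compound 4 (0.03 log units; within the scatter) is therefore expected to stay within the usual scatter. For compound 4 the expected value in this assay is 7000 nM, with a range from 3000 nM to 16000 nM.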

Compound 4, half-maximal inhibitory concentration: 9290 nM
Beside the measured number, compound 4's estimate is 1.3-fold (0.12 log units) below it; the range from low to high includes it.
By their numbers in this assay, from the lowest: compounds 3 and 4 (each within the scatter of the next); then compounds 2 and 1 (each within the scatter of the next).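

In this assay, for the compounds shown here, the step of a 1.4-fold higher number from compound 3 to compound 4 (0.15 log units; within the scatter) gives the first isolated reading of the sulfanyl chain, with the 2-hydroxynaphthalen-1-yl arm held constant. Exchanging propargylsulfanyl for propylsulfanyl removes the triple bond outside aromatic rings without moving the number beyond the scatter, so on this arm the two chains cannot be told apart in this read-out. No available evidence bears on this result.

From the compounds shown here alone, whether the two chains also read alike on other hydrazone arms, such as the 4-(dimethylamino)phenyl arm of compound 2, remains open. Also open, going by these compounds, is how this position responds to a clearly different chain, such as a longer butyl or hexyl chain on the sulfur or a chain ending in an amine or a carboxylic acid.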